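The source may report more compounds than this note shows. Statements on the series, on what has been measured and on what is new or still open speak of the compounds shown alone.

Of the compounds shown here, three sharing one core have been measured in an assay on CHO cells for displacement of a labelled ligand from adenosine receptor A3 (Homo sapiens), read by scintillation counting, with a stated time of 60 min; on this read-out lower numbers stand for stronger inhibition and higher numbers for weaker inhibition. Compound 1 `Cc1nc(NC(=O)c2ccccc2)c2nn(-c3ccccc3)cc2n1` gives 5.6 nM, the lowest of the three numbers. Compound 2 `CC(=O)Nc1nc(C)nc2cn(-c3ccccc3)nc12` gives 300 nM, and compound 3 `O=C(Nc1nc(-c2ccccc2)nc2cn(-c3ccccc3)nc12)c1ccccc1` gives 20 nM. The nearest neighbour of compound 1 in this assay is compound 3, and the furthest is compound 2. The change of methyl in place of phenyl on a carbonyl carbon brought a 54-fold higher number from compound 1 to compound 2 (1.73 log units; beyond the scatter), while phenyl in place of methyl on an aromatic carbon brought a 3.6-fold higher number from compound 1 to compound 3 (0.55 log units; beyond the scatter).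

Compound 4 `Cc1nc(N(C(=O)c2ccccc2)C(=O)c2ccccc2)c2nn(-c3ccccc3)cc2n1` is the next compound of interest; it differs from compound 1 by benzoyl in place of hydrogen on an amide-type nitrogen. Neither of the two measured steps touches the amide-type nitrogen, so neither bears directly on this change. Both do show that, among these three compounds, every alteration made so far to compound 1 has raised the number. Compound 1 carries an amide hydrogen that compound 4 no longer has, and a second benzoyl now sits where that hydrogen was. The expectation is therefore a weaker result for compound 4, with an 11-fold higher number from compound 1 to compound 4 (1.03 log units; beyond the scatter) as the estimated step. Compound 4 is expected to give about 60 nM in this assay, within a range from 8 nM to 500 nM.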

Compound 4, inhibition constant: 33 nM
Compound 4: middle estimate off by 1.8-fold (0.26 log units), on the high side; the measured number falls inside the stated range.
By their numbers in this assay, from the lowest: compound 1; then compounds 3 and 4 (each within the scatter of the next); then compound 2.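

Putting benzoyl in place of the amide hydrogen brought a 5.9-fold higher number from compound 1 to compound 4 (0.77 log units; beyond the scatter) in this assay, a rise that is real but modest for a change that adds 8 heavy atoms, including a whole aromatic ring, to the amide-type nitrogen. For the compounds shown here, this is the first look at that nitrogen, and it shows that the amide hydrogen is not needed for a low number, since compound 4, which lacks it, still gives 33 nM. Nothing shown here explains why the number rises at this position.

Going by these compounds alone, the single step changes two things at once, removing the amide hydrogen and adding a second benzoyl, so the share of each in the rise cannot be separated. As far as these compounds go, a simple methyl group on the same nitrogen, or a smaller acyl group such as acetyl in place of the second benzoyl, would be the natural comparison, and how either would read in this assay remains open.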